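The source may hold more compounds than are shown below. What is called first, only, known or untested is meant among the compounds shown, and "the series" means these compounds.

Measured so far in an assay on isolated protein for inhibition of Long-chain-fatty-acid--CoA ligase 1 (Homo sapiens), read by mass spectrometry, with a stated time of 90 min, in the presence of a further agent that is not named here; a higher number here means a weaker inhibitor, a lower number a stronger inhibitor:
- compound 1 `Cc1cccc(Cc2nc3cc(O[C@H]4CC[C@@H](C(=O)O)CC4)ccc3n2C)c1`, 42 nM
- compound 2 `Cn1c(Cc2cccc(C#N)c2)nc2cc(O[C@H]3CC[C@@H](C(=O)O)CC3)ccc21`, 51000 nM
- compound 3 `Cn1c(Cc2cccnc2)nc2cc(O[C@H]3CC[C@@H](C(=O)O)CC3)ccc21`, 141000 nM

Compound 3 stands at the highest number of the three. Its nearest neighbour is compound 2, with a 2.8-fold higher number from compound 2 to compound 3 (0.44 log units; beyond the scatter); its furthest is compound 1, with a 3400-fold higher number from compound 1 to compound 3 (3.53 log units; beyond the scatter).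

Compound 4 `Cn1c(Cc2ccc3c(c2)OCC3)nc2cc(O[C@H]3CC[C@@H](C(=O)O)CC3)ccc21` differs from compound 3 by a group of 9 heavy atoms (8 carbon, 1 oxygen; one five-membered non-aromatic ring with 1 hetero atom, one six-membered aromatic ring of carbon only) in place of a group of 6 heavy atoms (5 carbon, 1 nitrogen; one six-membered aromatic ring with 1 hetero atom), on a saturated chain carbon bound to an aromatic carbon. Among the measured compounds shown here, two measured steps bear on this change. The step of a 3400-fold higher number from compound 1 to compound 3 (3.53 log units; beyond the scatter) was large, with the pyridin-3-yl group entering. The step of a 2.8-fold higher number from compound 2 to compound 3 (0.44 log units; beyond the scatter) was modest, again with the pyridin-3-yl group entering. Compound 4 removes that group and returns to a six-membered aromatic ring of carbon only, as in compound 1, so a large step back down is expected: a 470-fold lower number from compound 3 to compound 4 (2.67 log units; beyond the scatter).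

Compound 4 is therefore estimated at 300 nM, with an expected range from 30 nM to 5000 nM.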

Compound 4, half-maximal inhibitory concentration: 13 nM
Beside the measured number, compound 4's estimate is 23-fold (1.36 log units) above it; the measured number lies below the stated range.
By their numbers in this assay, from the lowest: compound 4; then compound 1; then compound 2; then compound 3.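

In this assay, the group of 9 heavy atoms on the saturated chain carbon bound to an aromatic carbon gives large gains over the pyridin-3-yl group an 11000-fold lower number from compound 3 to compound 4 (4.04 log units; beyond the scatter) and the 3-cyanophenyl group a 3900-fold lower number from compound 2 to compound 4 (3.59 log units; beyond the scatter) and still improves on the 3-methylphenyl group a 3.2-fold lower number from compound 1 to compound 4 (0.51 log units; beyond the scatter) in a modest step. Compound 3 and compound 4 have the same printed hydrogen-bond acceptor count, so that count does not separate them. Nothing available explains these differences.

On these data alone, it remains open whether the ring oxygen of compound 4 contributes, which an indanyl group at this place would test. A 3-methoxyphenyl group would test whether the closed ring is needed.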